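The source may report more compounds than this note shows. Statements on the series, on what has been measured and on what is new or still open speak of the compounds shown alone.

Measured in a physicochemical assay for solubility, using the shake flask method, in simulated intestinal fluid, measured as kinetic solubility, with a stated time of 2 h, at 25 degrees C, at pH 6.5; on this read-out higher numbers stand for higher solubility and lower numbers for lower solubility:
- compound 1 `CCOC(=O)c1nc(C)c2c(c1N)C(=O)N(Cc1ccccc1)C2=O`: < 5000 nM (a limit of the assay, not a number)
- compound 2 `Cc1nc(C(=O)O)c(N)c2c1C(=O)N(Cc1ccccc1)C2=O`: 177000 nM
- compound 3 `Cc1nc(C(=O)OC2CC2)c(N)c2c1C(=O)N(Cc1ccccc1)C2=O`: 202000 nM

Compound 3 stands level with compound 2 within the scatter, a 1.1-fold higher number from compound 2 to compound 3 (0.06 log units; within the scatter). Two large steps, an at least 35-fold higher number from compound 1 to compound 2 (1.54 log units; beyond the scatter) and an at least 40-fold higher number from compound 1 to compound 3 (1.60 log units; beyond the scatter), both start from the limit of < 5000 nM in this assay, at which 1 of the 3 values shown sits.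

Compound 4 `Cc1nc(C(=O)N(C)C)c(N)c2c1C(=O)N(Cc1ccccc1)C2=O` differs from compound 3 in one place: dimethylamino in place of cyclopropyloxy on a carbonyl carbon. In words, dimethylamino stands in place of cyclopropyloxy on a carbonyl carbon. Among the measured compounds shown here, no measured step makes this exact change. The nearest guide is a 1.1-fold higher number from compound 2 to compound 3 (0.06 log units; within the scatter), a change on the same carbonyl carbon, while the large steps argue for a wide range. The expected size is no more than the scatter, with no clear direction: a 1.3-fold lower number from compound 3 to compound 4 (0.13 log units; within the scatter). The estimate for compound 4 is 150000 nM, with an expected range of 40000 nM to 400000 nM.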

Compound 4, solubility: 172000 nM
Compound 4: middle estimate off by 1.1-fold (0.06 log units), on the low side; the range from low to high includes it.
By their numbers in this assay, from the lowest: compounds 4, 2 and 3 (each within the scatter of the next). At a limit, below all of these: compound 1.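

In this assay, dimethylamino on this carbonyl carbon stands level with cyclopropyloxy (a 1.2-fold lower number from compound 3 to compound 4 (0.07 log units; within the scatter)) and with hydroxy (a 1.0-fold lower number from compound 2 to compound 4 (0.01 log units; within the scatter)). A group joined through nitrogen therefore sits with two joined through oxygen, and among the groups shown only ethoxy stands apart (an at least 34-fold higher number from compound 1 to compound 4 (1.53 log units; beyond the scatter)). That step starts from compound 1, whose value is a limit and not a number: the limit of < 5000 nM in this assay, at which 1 of the 4 values shown sits.

Still open, as far as these compounds go, is whether a morpholine or a longer chain on this carbonyl carbon would stay at this level or drop toward compound 1. Ethoxy and cyclopropyloxy differ widely. The compounds shown do not tell what lies behind this difference.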